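Working notes: changing the piperazine-side group of compound 2

The compounds below may be only part of what the source reports. "The series", "measured", "known", "first", "only" and "open" are said of these compounds alone.

Measured so far in a functional assay on HCT-116 cells (Homo sapiens) for inhibition, read by MTT assay, with a stated time of 72 h; a higher number here means a weaker inhibitor of growth, a lower number a stronger inhibitor of growth:
compound 1 `Cc1cc(CN2CCN(c3c(Br)cnc4[nH]c(N5CCN(Cn6cccn6)CC5)nc34)CC2)no1` (120 nM)
compound 2 `CN(C)c1ccc(-c2nc3c(N4CCN(CC(=O)Nc5cccnc5)CC4)c(Br)cnc3[nH]2)cc1` (1650 nM)
compound 3 `Cc1cc(CN2CCN(c3c(Br)cnc4[nH]c(-c5ccc(CN(C)C)cc5)nc34)CC2)no1` (230 nM)

Compound 2 has the highest number of the three, and its distance to each of the other two lies beyond the scatter, so it is the weakest inhibitor of growth in this small set. Compound 1 and compound 3 lie within the scatter of each other.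

The next compound is compound 4 `CC(c1ccncc1)N1CCN(c2c(Br)cnc3[nH]c(-c4ccc(N(C)C)cc4)nc23)CC1`, which has 1-(pyridin-4-yl)ethyl in place of ((pyridin-3-yl)carbamoyl)methyl on an amine nitrogen in a ring. The counted difference is 1-(pyridin-4-yl)ethyl in place of ((pyridin-3-yl)carbamoyl)methyl on an amine nitrogen in a ring and the rest of compound 2 stays as it is.

Among the measured compounds shown here, no measured pair isolates this change, so the expectation rests on indirect evidence only. Compound 3 (230 nM) also lacks the carbamoyl group on that nitrogen, although it differs from compound 2 elsewhere too, and it gives a clearly lower number. A move towards stronger inhibition of growth, probably beyond the scatter, is therefore expected. The estimated step is a 3.7-fold lower number from compound 2 to compound 4 (0.56 log units; beyond the scatter) in this assay on this reasoning. For compound 4 the expected value is 450 nM with an estimated range from 150 nM to 1300 nM at this stage.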

Compound 4, concentration for 50% growth inhibition: 900 nM
The estimate for compound 4 lay 2.0-fold (0.30 log units) below the measured number; the measured number falls inside the stated range.
By their numbers in this assay, from the lowest: compounds 1 and 3 (each within the scatter of the next); then compounds 4 and 2 (each within the scatter of the next).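

In this assay, the one-place step at this amine nitrogen gives a 1.8-fold lower number from compound 2 to compound 4 (0.26 log units; within the scatter). Among the compounds shown here, this is the first pair that isolates the group on this nitrogen with the rest of compound 2 held fixed: 1-(pyridin-4-yl)ethyl carries no carbonyl and no hydrogen-bond donor, and its ring is pyridin-4-yl rather than pyridin-3-yl, yet compound 2 and compound 4 cannot be told apart in this assay. The swap of ((pyridin-3-yl)carbamoyl)methyl for 1-(pyridin-4-yl)ethyl is therefore not enough on its own to separate the two compounds, and no measurement shown offers a reason for this result.

The group on the same nitrogen in compound 1 and compound 3 has no partner differing from compound 2 or compound 4 in one place only, so what it contributes cannot be read from these numbers. Going by these compounds, it also remains open whether this position tolerates a different kind of substituent altogether, such as a carboxylic acid, a simple methyl or a longer chain ending in a pyridine ring.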